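The source may report more compounds than this note shows. Statements on the series, on what has been measured and on what is new or still open speak of the compounds shown alone.

Measured to date in a functional assay on HL-60 cells (Homo sapiens) for antiproliferative activity, read by MTT assay, with a stated time of 72 h; on this read-out higher numbers stand for weaker inhibition and lower numbers for stronger inhibition:
- compound 1, `NC1=NC2(CCSCC2)N(OCCCOc2cccc(Cl)c2)C(N)=N1`: 260 nM
- compound 2, `NC1=NC2(CCSCC2)N(OCCCOc2ccc(Br)cc2)C(N)=N1`: 350 nM
- compound 3, `COc1ccc(OCCCON2C(N)=NC(N)=NC23CCSCC3)cc1`: 500 nM

Going by the values given here, of the three numbers, the one for compound 3 is the highest, but its separation from the others is small: a 1.9-fold higher number from compound 1 to compound 3 (0.28 log units; within the scatter) and a 1.4-fold higher number from compound 2 to compound 3 (0.15 log units; within the scatter), both within the scatter, so no order among the three compounds can be read from these values. Every exchange made so far sits on the aryl group attached to the oxygen on a saturated carbon, and each of them, including a 1.3-fold higher number from compound 1 to compound 2 (0.13 log units; within the scatter), has stayed within the scatter.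

Compound 4, `NC1=NC2(CCSCC2)N(OCCCOc2ccccc2Cl)C(N)=N1`, varies the same position: 2-chlorophenyl in place of 4-methoxyphenyl on an oxygen on a saturated carbon. Among the compounds with values here, no measured step involves a 2-chlorophenyl directly. Within the data shown here, the steps that bear on it are those that remove 4-methoxyphenyl, a 1.9-fold higher number from compound 1 to compound 3 (0.28 log units; within the scatter) and a 1.4-fold higher number from compound 2 to compound 3 (0.15 log units; within the scatter); both show that swapping this aryl group has so far moved the number only within the scatter, with compound 1, carrying 3-chlorophenyl, at the lower end of the spread. Compound 4 is therefore expected to show a 1.4-fold lower number from compound 3 to compound 4 (0.15 log units; within the scatter), a drift toward lower numbers that does not clear the scatter. The estimate for compound 4 in this assay is 350 nM, with a range of 150 nM to 800 nM.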

Compound 4, half-maximal inhibitory concentration: 390 nM
Compound 4: the middle estimate sits 1.1-fold (0.05 log units) below what was measured; the range from low to high includes it.
By their numbers in this assay, from the lowest: compounds 1, 2, 4 and 3 (each within the scatter of the next).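

In this assay, 2-chlorophenyl on an oxygen on a saturated carbon stays within the scatter of all three earlier aryl groups, with a 1.3-fold lower number from compound 3 to compound 4 (0.11 log units; within the scatter) and a 1.1-fold higher number from compound 2 to compound 4 (0.05 log units; within the scatter) and also a 1.5-fold higher number from compound 1 to compound 4 (0.18 log units; within the scatter) as the three steps. Going by these compounds alone, the last of these is the first exchange in which the aryl group keeps the same atoms, 2-chlorophenyl in place of 3-chlorophenyl, and it too gives no readable change. Four aryl groups at this position, carrying chlorine, bromine or methoxy, now cannot be told apart by their numbers, and no measured evidence on hand accounts for this.

The compounds shown leave open whether a different kind of group on this oxygen, such as a pyridine ring, a phenyl bearing a carboxylic acid or an amine, or a plain alkyl chain, would move the number beyond the scatter. Also open, on these data alone, is whether a longer chain on the oxygen of the shared core would change how these aryl exchanges read.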